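Moving a methoxy group within a level series

This account rests on a few compounds, and the source may have more. Where it says the series, first, only, none or still open, it means among the compounds named here.

In a functional assay on MCF7 cells (Homo sapiens) for cytotoxicity, read by MTT assay, with a stated time of 72 h (a lower number here means a stronger inhibitor, a higher number a weaker inhibitor), three compounds built on a shared core have been measured. Compound 1 `COc1ccc(/C=C2\CCC/C(=C\c3cccc(Cl)c3)C2=O)cc1OC` gives 6000 nM, compound 2 `COc1ccc(/C=C2\CCC/C(=C\c3ccc(Cl)cc3)C2=O)cc1OC` gives 6300 nM, and compound 3 `COc1ccccc1/C=C1\CCC/C(=C\c2ccc(OC)c(OC)c2)C1=O` gives 8000 nM. Compound 3 therefore stands level with the other two: the steps are a 1.3-fold higher number from compound 1 to compound 3 (0.12 log units; within the scatter) and a 1.3-fold higher number from compound 2 to compound 3 (0.10 log units; within the scatter).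

The unmeasured compound 4 `COc1ccc(/C=C2\CCC/C(=C\c3ccc(OC)c(OC)c3)C2=O)cc1` has the same atoms as compound 3, joined differently: 4-methoxyphenyl in place of 2-methoxyphenyl on a double-bonded chain carbon bound to a double-bonded ring carbon. All three measured steps changed the aromatic group at this same place, and none left the scatter. The closest in kind is a 1.1-fold higher number from compound 1 to compound 2 (0.02 log units; within the scatter), where one chlorophenyl group replaces another with the same atoms. Among the measured compounds shown here, no measured compound yet carries 4-methoxyphenyl at this place, so this remains an extrapolation from only three compounds.

The expected change is a 1.1-fold lower number from compound 3 to compound 4 (0.06 log units; within the scatter), so no step beyond the scatter is anticipated. For compound 4 the estimated value is 7000 nM, with an expected range from 3000 nM to 15000 nM.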

Compound 4, half-maximal inhibitory concentration: 7800 nM
Compound 4: middle estimate off by 1.1-fold (0.05 log units), on the low side; low and high end bracket the measured number.
By their numbers in this assay, from the lowest: compounds 1, 2, 4 and 3 (each within the scatter of the next).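

Within this assay the swap of 2-methoxyphenyl for 4-methoxyphenyl on a double-bonded chain carbon bound to a double-bonded ring carbon gives (a 1.0-fold lower number from compound 3 to compound 4 (0.01 log units; within the scatter)), so moving the methoxy group around this ring, with the atoms unchanged, leaves the two compounds level. Methoxy in place of chloro on an aromatic carbon also stays level (a 1.2-fold higher number from compound 2 to compound 4 (0.09 log units; within the scatter)), as does the swap of 3-chlorophenyl for 4-methoxyphenyl (a 1.3-fold higher number from compound 1 to compound 4 (0.11 log units; within the scatter)), so all four compounds now tell the same story at this place, and neither the kind of group nor where it sits on the ring separates them. Nothing available explains why these compounds are so alike.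

Among the compounds shown here, every group at this place so far is a phenyl ring carrying chloro or methoxy. From the compounds shown here alone, whether an amine or a carboxylic acid on that ring, or a longer chain in its stead, would move the number beyond the scatter remains open.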